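The source may report more compounds than this note shows. Statements on the series, on what has been measured and on what is new or still open speak of the compounds shown alone.

Compound 1 `N[C@H](C(=O)OCCCOC1(c2ccc(Cl)cc2)c2ccccc2C(=O)N1Cc1ccccc1)c1ccccc1` is assessed in a functional assay on HCT-116 cells (Homo sapiens) for inhibition, read by fluorescence, with a stated time of 48 h (a higher number here means a weaker inhibitor of growth, a lower number a stronger inhibitor of growth), where compound 1 gives 43000 nM. That is the lowest of the two numbers recorded, and its nearest neighbour is compound 2 `N[C@H](C(=O)OCCCOC1(c2ccc(Cl)cc2)c2ccccc2C(=O)N1Cc1ccc(Cl)cc1)c1ccccc1`, which in this assay gives 45000 nM. Within the data shown here, the one step that is known, a 1.0-fold higher number from compound 1 to compound 2 (0.02 log units; within the scatter), arises from a chloro in place of hydrogen on an aromatic carbon and leaves the number unchanged within the scatter.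

Compound 3 `O=C1c2ccccc2C(OCCCO)(c2ccc(Cl)cc2)N1Cc1ccccc1` differs from compound 1 at another part of the molecule: hydrogen in place of (amino(phenyl)methyl)carbonyl on an oxygen on a saturated carbon. Among the measured compounds shown here, no measured step touches this oxygen or the group that leaves it, so the only step on record, between compound 1 and compound 2, is a change elsewhere and does not bear on the question. On the evidence of compound 1 alone, with its value of 43000 nM, the size and direction of the effect cannot be read from the data.

For compound 3 the expectation is therefore 50000 nM in this assay, with a range from 18000 nM to 140000 nM. The step this estimate implies, a 1.2-fold higher number from compound 1 to compound 3 (0.07 log units; within the scatter), is expected to be no larger than the scatter.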

Compound 3, concentration for 50% growth inhibition: 90000 nM
Compound 3: the middle estimate sits 1.8-fold (0.26 log units) below what was measured; measured number inside the range.
By their numbers in this assay, from the lowest: compounds 1, 2 and 3 (each within the scatter of the next, the first and the last beyond it).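

In this assay, among these compounds, the step of a 2.1-fold higher number from compound 1 to compound 3 (0.32 log units; beyond the scatter) is the first on record at this oxygen on a saturated carbon, and it shows that the number responds to a change here: with hydrogen in place of (amino(phenyl)methyl)carbonyl, the compound is a modestly weaker inhibitor of growth. The earlier step of a 1.0-fold higher number from compound 1 to compound 2 (0.02 log units; within the scatter) stayed within the scatter, so the two changes on record differ in outcome, with only this one going beyond it. Nothing in the data shown accounts for the change at this oxygen.

The compounds shown leave open which part of the (amino(phenyl)methyl)carbonyl group carries the step, since the amine, the phenyl ring and the carbonyl all leave together, and a simple acetyl on the same oxygen would begin to separate them. Also open, from the compounds shown here alone, is whether the step would persist with a longer chain carrying the same group, or whether it would grow or shrink on the core of compound 2.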